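A six-membered ring in place of a five-membered one

The compounds below may be only part of what the source reports. "The series", "measured", "known", "first", "only" and "open" are said of these compounds alone.

In a functional assay on HepG2 cells (Homo sapiens) for inhibition, read by MTT assay, with a stated time of 48 h (on this read-out higher numbers stand for weaker inhibition and lower numbers for stronger inhibition), compound 1 (`COc1ccc(/C=C\c2cc(OC)c(OC)c(OC)c2)cc1OC(=O)C1=CC(C)(C)N(O)C1(C)C`) gives 3270 nM and compound 2 (`COc1ccc(/C=C\c2cc(OC)c(OC)c(OC)c2)cc1OC(=O)C1CC(C)(C)N(O)C1(C)C`) gives 1830 nM. These numbers lie within the scatter of each other, so compound 2 cannot be told apart from compound 1 on this read-out. Compound 3 (`COc1ccc(/C=C\c2cc(OC)c(OC)c(OC)c2)cc1OC(=O)C1=CC(C)(C)N(O)C(C)(C)C1`) has yet to be measured. It differs from compound 2 by a group of 11 heavy atoms (9 carbon, 1 nitrogen, 1 oxygen; one six-membered non-aromatic ring with 1 hetero atom) in place of a group of 10 heavy atoms (8 carbon, 1 nitrogen, 1 oxygen; one five-membered non-aromatic ring with 1 hetero atom), on a carbonyl carbon. The entering group also has 1 double bond outside aromatic rings. Within the data shown here, only one measured step bears on this change: a 1.8-fold lower number from compound 1 to compound 2 (0.25 log units; within the scatter), which exchanges one five-membered non-aromatic ring for another at the same place. Among the measured compounds shown here, no measured compound carries the six-membered ring, so this guide is only partial. The expected change is a 1.3-fold higher number from compound 2 to compound 3 (0.12 log units; within the scatter), which would be no step beyond the scatter. In this assay, the estimate for compound 3 is 2400 nM, with an expected range of 800 nM to 7000 nM.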

Compound 3, half-maximal inhibitory concentration: 3580 nM
For compound 3 the middle estimate is 1.5-fold (0.17 log units) below the measured one, and the stated range covers the measured number.
By their numbers in this assay, from the lowest: compounds 2, 1 and 3 (each within the scatter of the next).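

In this assay, replacing the five-membered ring of compound 2 with the six-membered ring gives a 2.0-fold higher number from compound 2 to compound 3 (0.29 log units; within the scatter), while the matching exchange for the other five-membered ring gives a 1.1-fold higher number from compound 1 to compound 3 (0.04 log units; within the scatter). The earlier pair compared only five-membered rings on the carbonyl carbon, and compound 3 now shows that a six-membered non-aromatic ring with a double bond outside aromatic rings cannot be told apart from either of them on this read-out. Nothing measured here explains why these three groups read alike.

The compounds shown leave open how the fully saturated six-membered ring, lacking that double bond, would read in this assay. They also leave open whether an open-chain amine or a carboxylic acid in this place would give a step beyond the scatter.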